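Aryl swap to thiophene on the fused core: solubility notes

A few compounds are considered here, and "the series" means these few. Any claim that something is new, unique, unknown or untested is made for them only; others in the source may bear on it.

Compound 3 `Cc1cc(NCc2ccccn2)n2ncc(-c3cc(F)c(F)c(F)c3)c2n1` gives in a physicochemical assay for solubility, read by HPLC, using the shake flask method, measured as kinetic solubility, with a stated time of 2 h, at pH 7.4 (a higher number here means a more soluble compound, a lower number a less soluble compound), only a limit, < 5000 nM. Compound 1 `COc1ccc(-c2cnn3c(NCc4ccccn4)cc(C)nc23)cc1` also reaches only a limit in this assay, < 5000 nM. Compound 2 `Cc1cc(NCc2ccccn2)n2ncc(-c3ccc(C#N)cc3)c2n1` likewise sits at a limit in this assay, < 5000 nM. the limit of < 5000 nM in this assay, at which 3 of the 3 values shown sit, describes where all three stand. The steps a step that the two limits leave unreadable from compound 1 to compound 2, a step that the two limits leave unreadable from compound 1 to compound 3 and a step that the two limits leave unreadable from compound 2 to compound 3 are accordingly unreadable in size. Compound 4 `Cc1cc(NCc2ccccn2)n2ncc(-c3ccsc3)c2n1` carries the change (thiophen-3-yl in place of 3,4,5-trifluorophenyl on an aromatic carbon). Within the data shown here, none of the measured steps gives a readable size for this change, so no direction beyond the scatter can be expected in this assay. Compound 4 is estimated at 4000 nM, in the range 1000 nM to 20000 nM. The expected step that the limit leaves unreadable from compound 3 to compound 4 is thus small, with a high chance that only a limit is again reported.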

Compound 4, solubility: 9000 nM
Compound 4: the middle estimate sits 2.3-fold (0.35 log units) below what was measured; low and high end bracket the measured number.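

Thiophen-3-yl is the only group at this position, an aromatic carbon of the shared core, that gives a number rather than a limit in this assay. The readable steps are an at least 1.8-fold higher number from compound 3 to compound 4 (0.25 log units; that floor lies within the scatter), an at least 1.8-fold higher number from compound 2 to compound 4 (0.25 log units; that floor lies within the scatter) and an at least 1.8-fold higher number from compound 1 to compound 4 (0.25 log units; that floor lies within the scatter), so each gives only a floor and not a full size. The three substituted phenyl groups all remain at a limit: the limit of < 5000 nM in this assay, at which 3 of the 4 values shown sit.

From the compounds shown here alone, the steps among compound 1, compound 2 and compound 3 cannot be read, and the true size of the steps to compound 4 stays open. Also open, going by these compounds, is whether an amine or a carboxylic acid on this aromatic carbon would give a number or another limit.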